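A Methoxy Group Added to the Imine Phenyl Ring

The source may hold more compounds than are shown below. What is called first, only, known or untested is meant among the compounds shown, and "the series" means these compounds.

Three compounds share one core. Compound 1 `Cc1ccc(-c2nn(-c3ccc(Cl)cc3)cc2C=O)cc1` gives 56% in a functional assay on the whole organism (strain Wistar albino) for inhibition, with Rattus norvegicus as the target, read by paw edema, with stated times of 1 h and 3 h, at a dose of 0.32 mmol/kg by the intraperitoneal route; on this read-out higher numbers stand for more inhibition at the one dose given (going by the name of the read-out) and lower numbers for less inhibition. Compound 2 `Cc1ccc(-c2nn(-c3ccc(S(N)(=O)=O)cc3)cc2C=O)cc1` gives 68.2%, and compound 3 `Cc1ccc(-c2nn(-c3ccc(Cl)cc3)cc2/C=N\c2ccccc2)cc1` gives 49.3%. Compound 3 holds the lowest of these three numbers, yet its gap to compound 1 lies within the scatter, while its gap to compound 2 lies beyond it. Compound 4 `COc1ccc(/N=C\c2cn(-c3ccc(Cl)cc3)nc2-c2ccc(C)cc2)cc1` differs from compound 3 by methoxy in place of hydrogen on an aromatic carbon. Among the measured compounds shown here, no measured step touches this ring: a number 12.2 percentage points higher from compound 1 to compound 2 (beyond the scatter) exchanged chloro for sulfamoyl on a different aromatic ring, and a number 6.7 percentage points lower from compound 1 to compound 3 (within the scatter) exchanged a small group for the larger one carrying the ring. Therefore no step beyond the scatter is expected; compound 4 is estimated at 52%, between 38% and 66%, the expected step being a number 2.7 percentage points higher from compound 3 to compound 4 (within the scatter).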

Compound 4, a percentage reported as inhibition, in the whole organism at one dose (the size of the read-out at that dose, not a potency): 48.9%
Beside the measured number, compound 4's estimate is 3.1 percentage points above it; measured number inside the range.
By their numbers in this assay, from the lowest: compounds 4, 3 and 1 (each within the scatter of the next); then compound 2.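

Among the compounds shown here, the change from phenyl to 4-methoxyphenyl gives a number 0.4 percentage points lower from compound 3 to compound 4 (within the scatter) in this assay and is the first measured step on this ring. At this place, para to a large group, methoxy in place of hydrogen therefore leaves the read-out within the scatter at the one dose given. Nothing measured here offers an explanation for this result. From the compounds shown here alone, whether an amine or a carboxylic acid at the same place would also stay within the scatter remains open. So does whether methoxy would act the same way on an imine carrying the sulfamoyl group of compound 2.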